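Bromo substitution on the core of compound 2

This account rests on a few compounds, and the source may have more. Where it says the series, first, only, none or still open, it means among the compounds named here.

Measured so far:
compound 1 `CNc1nc(O)c(Br)c(-c2ccccc2)n1` — 42%
compound 2 `Cn1c(-c2ccccc2)cc(=O)[nH]c1=O` — 27%

In a functional assay on the whole organism for inhibition, with Rattus norvegicus as the target, at a dose of 25 mg/kg by the oral route (a higher number here means a stronger effect of the compound at the dose given, a lower number a weaker effect), compound 1 gives 42%. In this assay compound 2 gives 27%, the lower of the two numbers recorded; the gap to compound 1 is beyond the usual scatter. Among the measured compounds shown here, compounds 1 and 2 differ in more than one place, so their two values show only that compound 1 sits higher, and nothing can be read from the pair about any single group.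

The next compound, compound 3 `Cn1c(-c2ccccc2)c(Br)c(=O)[nH]c1=O`, differs from compound 2 in one place: bromo in place of hydrogen on an aromatic carbon. The entering bromine sits on the six-membered aromatic ring of the shared core, ortho to the group of 6 heavy atoms and two atoms from the ring nitrogen.

For the measured compounds named here, no single-change step between measured compounds is available, so the size of the step from compound 2 to compound 3 in this assay is expected to be modest, most likely a small rise and possibly none beyond the scatter. For compound 3 the expected step is a number 8 percentage points higher from compound 2 to compound 3 (within the scatter). Compound 3 is estimated at 35%, with a range from 15% to 55%.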

Compound 3, a percentage reported as inhibition, in the whole organism at one dose (the size of the read-out at that dose, not a potency): 22%
The estimate for compound 3 lay 13 percentage points above the measured number; measured number inside the range.
By their numbers in this assay, from the lowest: compounds 3 and 2 (each within the scatter of the next); then compound 1.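

In this assay, among the compounds shown here, bromo in place of hydrogen on an aromatic carbon gives a number 5 percentage points lower from compound 2 to compound 3 (within the scatter), the first single-change step that can be read. At this position, ortho to the group of 6 heavy atoms and two atoms from the ring nitrogen, the entering bromo group leaves compound 3 indistinguishable from compound 2 at the dose given, so this step shows no gain or loss beyond the scatter. Nothing on hand bears on why the step has this size. The step also applies only to the core of compound 2, and it says nothing about the bromo group on the core of compound 1, which differs from compound 3 in more than one place.

On these data alone, it remains open whether a chloro group, a methyl group, an amine or a carboxylic acid on this same aromatic carbon would give a step beyond the scatter. Also open, as far as these compounds go, is whether the picture for compound 2 and compound 3 would hold at other doses, as the read-out here comes from a single dose.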